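The compounds below may be only part of what the source reports. "The series", "measured", "known", "first", "only" and "open" are said of these compounds alone.

Measured compounds in this series:

compound 1 `Cc1ccc(CNC(=O)C(C)c2ccc(NS(C)(=O)=O)c(F)c2)cc1`: 3100 nM
compound 2 `CC(C(=O)NCc1ccc(C2C=CCC2)cc1)c1ccc(NS(C)(=O)=O)c(F)c1`: 162 nM
compound 3 `CC(C(=O)NCCC(c1ccc(F)cc1)c1ccc(F)cc1)c1ccc(NS(C)(=O)=O)c(F)c1`: 79 nM

In an assay on CHO cells for displacement of a labelled ligand from transient receptor potential cation channel subfamily V member 1 (Rattus norvegicus) (a lower number here means a stronger inhibitor, a higher number a weaker inhibitor), compound 3 gives the lowest number of the three; compound 2 stands somewhat above it and compound 1 far above, so compound 3 is the reference point of the set.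

Compound 4 `Cc1ccc(C(CCNC(=O)C(C)c2ccc(NS(C)(=O)=O)c(F)c2)c2ccc(F)cc2)cc1` differs from compound 3 by methyl in place of fluoro on an aromatic carbon. Within the data shown here, the only measured single step, a 19-fold lower number from compound 1 to compound 2 (1.28 log units; beyond the scatter), concerns a different change and does not bear on a fluoro-to-methyl exchange; no measured pair shows that swap. With nothing to drive the number either way, the step from compound 3 to compound 4 in this assay is expected to be a 1.0-fold higher number from compound 3 to compound 4 (0.01 log units; within the scatter), within the scatter. Compound 4 is estimated at 80 nM, with a range from 30 nM to 250 nM.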

Compound 4, inhibition constant: 121 nM
For compound 4 the middle estimate is 1.5-fold (0.18 log units) below the measured one, within the range that was stated.
By their numbers in this assay, from the lowest: compounds 3, 4 and 2 (each within the scatter of the next, the first and the last beyond it); then compound 1.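

In this assay, methyl in place of fluoro on the aromatic carbon para to a large group gives a 1.5-fold higher number from compound 3 to compound 4 (0.19 log units; within the scatter), so this position accepts either group without a change beyond the scatter. Among these compounds, this is the first reading of any exchange at this position, and it concerns only these two small groups. No available evidence bears on the result.

Going by these compounds, the outcome with a larger or differently charged group at this position, such as ethyl, an amine or a carboxylic acid, remains open. So does the same exchange on the remaining 4-fluorophenyl.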